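A few compounds are considered here, and "the series" means these few. Any claim that something is new, unique, unknown or untested is made for them only; others in the source may bear on it.

Measured so far:
Compound 1 `COC(=O)c1ccc(NCc2cncn2Cc2ccc(C)cc2)cc1-c1ccccc1`: in a toxicity assay on NIH3T3 cells (Mus musculus) for cytotoxicity, read by resazurin assay (a lower number here means that less compound is needed, a higher number that more compound is needed for the effect), compound 1 gives 50000 nM.
Compound 2 `O=[N+]([O-])c1ccc(Cn2cncc2CNc2cccc(-c3ccccc3)c2)cc1`: in this assay compound 2 gives 10000 nM.

Compound 2 holds the lowest of the two numbers; compound 1 sits at a higher number, and that gap is beyond the scatter. Compound 3 `Cc1ccc(Cn2cncc2CNc2cccc(-c3ccccc3)c2)cc1` is not yet measured and differs from compound 2 by methyl in place of nitro on an aromatic carbon. Among the compounds with values here, no step between measured compounds isolates this change, so its size has no direct precedent here. In this assay a modest step toward a higher number is expected: a 2.0-fold higher number from compound 2 to compound 3 (0.30 log units; within the scatter). Compound 3 is estimated at 20000 nM, with a range from 6000 nM to 60000 nM.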

Compound 3, half-maximal effective concentration: 10000 nM
Beside the measured number, compound 3's estimate is 2.0-fold (0.30 log units) above it; the measured number falls inside the stated range.
By their numbers in this assay, from the lowest: compounds 2 and 3 (each within the scatter of the next); then compound 1.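

Methyl in place of nitro para to a large group gives no change at the digits printed from compound 2 to compound 3 (within the scatter) in this assay and so, for these two groups, the number does not depend on which one sits at this position. Hydrogen in place of methoxycarbonyl on an aromatic carbon gives a 5.0-fold lower number from compound 1 to compound 3 (0.70 log units; beyond the scatter) as the only step shown beyond the scatter, which puts the shift seen so far at that site rather than on the 4-methylphenyl group. Nothing available bears on the reason for either step.

On these data alone, whether an amine or a carboxylic acid at the nitro position would move the number stays open. So does the effect of a replacement for methoxycarbonyl other than hydrogen, such as a longer chain.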